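The source may report more compounds than this note shows. Statements on the series, on what has been measured and on what is new or still open speak of the compounds shown alone.

Working notes on the series. Compound 2 `COc1ccc2[nH]c3c(c2c1)CCNC31CCN(Cc2ccc(F)c(Cl)c2F)CC1` gives 4500 nM in an assay on FRT cells for positive allosteric modulation of Cystic fibrosis transmembrane conductance regulator variant N1303K (Homo sapiens), in the presence of a further agent that is not named here (on this read-out higher numbers stand for an effect only at larger amounts of compound and lower numbers for an effect already at smaller amounts), the higher of the two numbers recorded so far; compound 1 `COc1ccc2[nH]c3c(c2c1)CCNC31CCN(Cc2ccc(Br)cc2F)CC1` gives 1600 nM. Among the compounds with values here, the only step between measured compounds is a 2.8-fold higher number from compound 1 to compound 2 (0.45 log units; beyond the scatter), which moved the number upward by a modest amount.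

Compound 3 `COc1ccc2[nH]c3c(c2c1)CCNC31CCN(Cc2cc(F)c(F)c(F)c2)CC1` has not been measured. It differs from compound 2 as follows: 3,4,5-trifluorophenyl in place of 3-chloro-2,4-difluorophenyl on a saturated chain carbon bound to an amine nitrogen in a ring. Within the data shown here, one measured step bears on this, the exchange of one halogenated benzyl group for another from compound 1 to compound 2, and it was modest. The new change keeps halogens on the same ring but alters their number and placement in a way not covered by that single step, so no direction can be read from the data.

For compound 3 the expected outcome is 3000 nM, with a range of 1200 nM to 8000 nM. The estimated step is therefore a 1.5-fold lower number from compound 2 to compound 3 (0.18 log units; within the scatter), expected to stay within the scatter.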

Compound 3, half-maximal effective concentration: 2600 nM
The estimate for compound 3 lay 1.2-fold (0.06 log units) above the measured number; low and high end bracket the measured number.
By their numbers in this assay, from the lowest: compounds 1, 3 and 2 (each within the scatter of the next, the first and the last beyond it).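

On a saturated chain carbon bound to an amine nitrogen in a ring, 3,4,5-trifluorophenyl in place of 3-chloro-2,4-difluorophenyl gives a 1.7-fold lower number from compound 2 to compound 3 (0.24 log units; within the scatter), and in place of 4-bromo-2-fluorophenyl it gives a 1.6-fold higher number from compound 1 to compound 3 (0.21 log units; within the scatter). In this assay, a phenyl group carrying fluorine as its only halogen therefore stays within the scatter of both earlier groups, which carry chlorine or bromine as well, while the gap between those two remains beyond the scatter. Nothing available explains these numbers.

The compounds shown leave open how a phenyl group with a nitrile or an amine in place of the halogens would read in this assay. They also leave open whether a longer chain between the phenyl group and the ring nitrogen would change the number.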